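What One Flipped Stereocentre May Do to Compound 2

A few compounds are considered here, and "the series" means these few. Any claim that something is new, unique, unknown or untested is made for them only; others in the source may bear on it.

- compound 1 `NCCCCN(C[C@H]1Cc2ncccc2CN1)[C@H]1CCCc2cccnc21`: 64%
- compound 2 `NCCCCN(C[C@H]1Cc2cccnc2CN1)[C@H]1CCCc2cccnc21`: 49%

These two values come from an ADME assay on microsomes from liver (Rattus norvegicus) for metabolic stability, using NADPH, with a stated time of 10 min; a higher number here means that more of the compound is left, a lower number that less of the compound is left. Compound 2 gives 49%, the lower of the two values, while compound 1, at 64%, lies higher by more than the usual scatter.

Compound 3 `NCCCCN(C[C@@H]1Cc2cccnc2CN1)[C@H]1CCCc2cccnc21` is a close relative of compound 2. The two compounds have the same atoms and bonds and differ only in configuration as drawn: the two compounds have the same atoms and bonds and differ only in configuration as drawn: 1 of 2 stereo elements differ; a stereocentre at a saturated ring carbon is drawn R in compound 2 and S in compound 3. A stereocentre at a saturated ring carbon is drawn R in compound 2 and S in compound 3.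

Within the data shown here, no measured pair here shows what such a change does in this assay, so neither the size nor the direction of the step can be read from the data. The expected step is therefore none beyond the scatter, with compound 2 at 49% as the starting point and a wide margin on both sides. This expectation corresponds to an estimated a number 3 percentage points higher from compound 2 to compound 3 (within the scatter).

For compound 3 the estimated value is 52%, with an expected range of 34% to 72%.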

Compound 3, percent of the compound remaining: 37%
The estimate for compound 3 lay 15 percentage points above the measured number; measured number inside the range.
By their numbers in this assay, from the lowest: compound 3; then compound 2; then compound 1.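

In this assay the configuration at the saturated ring carbon proves to matter: drawing this stereocentre S instead of R gives a number 12 percentage points lower from compound 2 to compound 3 (beyond the scatter). Among these compounds, compound 1 and compound 2 could not show this, since they differ in more than the drawing of one centre, so this is the first reading of a single change at this position, and it points to less of the compound being left after the flip. The step can be tied to this one stereocentre and to nothing else in the structure because of a single fact: the fact that compounds 2 and 3 differ only in the configuration as drawn.

The compounds shown leave open what the other stereocentre contributes, since it is drawn alike in all three, and whether the same flip would lower the number for compound 1 as well. Also open, going by these compounds, is how a fluorine or a carboxylic acid on the shared core, or a longer chain in place of the one that carries the amine, would shift the amount left in this assay and whether the preference for the R drawing would survive such a change.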